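Amine-aryl variation on the shared core: compound 3

A few compounds are considered here, and "the series" means these few. Any claim that something is new, unique, unknown or untested is made for them only; others in the source may bear on it.

Measured so far:
Compound 1, `O=C(/C=C\Nc1ccc2[nH]ccc2c1)c1nc(-c2ccc(C(F)(F)F)cc2)n2ccccc12`: in a functional assay on HCT-116 cells (Homo sapiens) for cytotoxicity, read by MTT assay, with a stated time of 48 h (on this read-out lower numbers stand for stronger inhibition and higher numbers for weaker inhibition), compound 1 gives 27100 nM.
Compound 2, `O=C(/C=C\Nc1ccc(F)cc1)c1nc(-c2ccc(C(F)(F)F)cc2)n2ccccc12`: in this assay compound 2 gives > 30000 nM, which is a limit of the assay and not a number.

Within the data shown here, compound 2 therefore stands at the limit of > 30000 nM in this assay, at which 1 of the 2 values shown sits; it sits no stronger than compound 1, and the single measured step, an at least 1.1-fold higher number from compound 1 to compound 2 (0.04 log units; that floor lies within the scatter), lies within the scatter. Compound 3, `O=C(/C=C\Nc1cnc2ccccc2c1)c1nc(-c2ccc(C(F)(F)F)cc2)n2ccccc12`, arises from compound 2 by quinolin-3-yl in place of 4-fluorophenyl on an amine nitrogen. Among the measured compounds shown here, the only step that bears on this change is the one just cited, where a bicyclic aromatic on the amine nitrogen was exchanged for 4-fluorophenyl without a shift beyond the scatter. Compound 3 returns a bicyclic aromatic to that nitrogen, so no step beyond the scatter is expected in this assay; the expected step is an at least 1.2-fold lower number from compound 2 to compound 3 (0.07 log units; that floor lies within the scatter). Compound 1 with its bicyclic aromatic gives 27100 nM. For compound 3 the estimate is 25000 nM, within 8000 nM to 80000 nM.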

Compound 3, half-maximal inhibitory concentration: > 30000 nM
Compound 3: no number, only a limit; the forecaster's own chance of this, stated with the estimate: 40%; middle value at least 1.2-fold (0.07 log units) from the limit.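

Quinolin-3-yl, a second bicyclic aromatic on the amine nitrogen, gives an at least 1.1-fold higher number from compound 1 to compound 3 (0.04 log units; that floor lies within the scatter) in this assay, so only a floor within the scatter separates it from 1H-indol-5-yl. The step between compound 2 and compound 3 cannot be read, as both values are limits of the assay. The hydrogen-bond acceptor that quinolin-3-yl brings still leaves compound 3 at a limit, and the compounds shown now gather there: the limit of > 30000 nM in this assay, at which 2 of the 3 values shown sit.

From the compounds shown here alone, it remains open whether a phenyl group carrying a carboxylic acid or a dimethylamino chain on that amine nitrogen would give a measurable number in this assay. Going by these compounds, how far compound 2 and compound 3 lie past their limits also stays open.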